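A few compounds are considered here, and "the series" means these few. Any claim that something is new, unique, unknown or untested is made for them only; others in the source may bear on it.

In a functional assay on MDA-MB-231 cells (Homo sapiens) for inhibition, read by MTT assay, with a stated time of 72 h (a higher number here means a weaker inhibitor, a lower number a stronger inhibitor), compound 1 `Nc1ncnc2c1c(-c1cnc3[nH]ccc3c1)nn2CC(=O)NO` gives > 150000 nM as a limit of the assay and not a number. Compound 2 `Nc1ncnc2c1c(-c1cnc3[nH]ccc3c1)nn2CCCCCCCCC(=O)NO` gives 11000 nM and compound 3 `Nc1nc2cc(-c3nn(CCCC(=O)NO)c4ncnc(N)c34)ccc2o1` gives 19500 nM as numbers. These two lie within the scatter of each other, so compound 3 stands level with compound 2 and no order can be read between them.

Compound 4 `Nc1nc2cc(-c3nn(CCCCCCCCCC(=O)NO)c4ncnc(N)c34)ccc2o1` is still unmeasured. It keeps the core of compound 3 and carries 6-(hydroxycarbamoyl)hexyl in place of hydroxycarbamoyl on a saturated chain carbon, three bonds along the chain from an aromatic nitrogen. Among the measured compounds shown here, no measured pair shares the core of compound 3 and differs only in the chain.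

In this assay a moderate fall in the number is expected, toward a stronger inhibitor. Compound 1 shares its core with compound 2 and reports only a limit. Compound 2 with its long chain gives 11000 nM as a number, and that is the only support for this expectation, so it is weak. The expected step is a 3.3-fold lower number from compound 3 to compound 4 (0.51 log units; beyond the scatter) and it may stay modest. For compound 4 the estimated value in this assay is 6000 nM with a range from 1800 nM to 20000 nM as expected bounds.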

Compound 4, half-maximal inhibitory concentration: > 50000 nM
Compound 4: only a limit was reported; the forecaster's own chance of this, stated with the estimate: 5%; at least 8.3-fold (0.92 log units) between middle value and limit.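

On the core of compound 3, 6-(hydroxycarbamoyl)hexyl in place of hydroxycarbamoyl on a saturated chain carbon, three bonds along the chain from an aromatic nitrogen, gives an at least 2.5-fold higher number from compound 3 to compound 4 (0.40 log units; beyond the scatter) in this assay. This is the only pair shown that shares this core and differs only in the chain, and the longer chain goes with a weaker inhibitor, so on this core a longer chain at this position brings no gain in this assay. The value of compound 4 is a limit of the assay and not a number, so the step is bounded from one side only: the limit of > 50000 nM in this assay, at which 1 of the 4 values shown sits.

On these data alone, compound 2 differs from compound 4 in more than one place, so the reading of its long chain on its own core cannot be set against this step, and whether chain length acts in the same direction on both cores stays open. Also open, as far as these compounds go, are the shape of the dependence on chain length on the core of compound 3, which chains of intermediate length would show, and whether a carboxylic acid in place of hydroxycarbamoyl at the chain end would change the reading.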